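Replacing the nitrooxy group on a shared core

The source may report more compounds than this note shows. Statements on the series, on what has been measured and on what is new or still open speak of the compounds shown alone.

Compound 1 `COC(=O)C1=C(C)N=C(C)/C(=C(/O)OC)C1c1ccccc1OCCO[N+](=O)[O-]`: 56 nM
Compound 2 `COC(=O)C1=C(C)N=C(C)/C(=C(/O)OC)C1c1cccc(OCc2no[n+]([O-])c2C(N)=O)c1`: 710 nM

In a functional assay (aorta) with Rattus norvegicus as the target, in the presence of a further agent that is not named here (on this read-out lower numbers stand for an effect already at smaller amounts and higher numbers for an effect only at larger amounts of compound), compound 1 gives 56 nM, the lower of the two numbers; compound 2 gives 710 nM, a gap beyond the usual scatter. Compound 3 `COC(=O)C1=C(C)N=C(C)/C(=C(/O)OC)C1c1ccccc1OCc1no[n+]([O-])c1C#N` is not yet measured. It differs from compound 1 by a group of 8 heavy atoms (3 carbon, 3 nitrogen, 2 oxygen; one five-membered aromatic ring with 3 hetero atoms) in place of a group of 5 heavy atoms (1 carbon, 1 nitrogen, 3 oxygen; no ring), on a saturated chain carbon bound to an oxygen on an aromatic ring. Among the compounds with values here, no measured pair shows this exact change, so the step can only be judged from the two numbers above. A modest move toward a higher number in this assay is expected, near the edge of the scatter, giving an estimated step of a 2.1-fold higher number from compound 1 to compound 3 (0.33 log units; beyond the scatter). Compound 3 is therefore expected at about 120 nM, within 30 nM to 500 nM.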

Compound 3, half-maximal effective concentration: 4.4 nM
The estimate for compound 3 lay 27-fold (1.44 log units) above the measured number; measured number outside the range, below it.
By their numbers in this assay, from the lowest: compound 3; then compound 1; then compound 2.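

In this assay, putting a five-membered aromatic ring with 3 hetero atoms, carrying a nitrile, in place of the (nitrooxy)methyl group on a saturated chain carbon bound to an oxygen on an aromatic ring gives a 13-fold lower number from compound 1 to compound 3 (1.10 log units; beyond the scatter). So, on this core, a low number does not depend on the nitrooxy group, and this larger group is accepted at this place. No measurement here explains the drop.

On these data alone, whether the nitrile matters remains open, and a carboxylic acid or an amine in its place would test this. As far as these compounds go, whether a longer chain to the ring keeps the low number is also open.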